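A Carboxyethyl Amide Variant of a Weak Cytotoxic Series

The source may hold more compounds than are shown below. What is called first, only, known or untested is meant among the compounds shown, and "the series" means these compounds.

Measured compounds:
compound 1, `CNC(=O)Cn1nc(N)c2c(C(F)(F)F)cc(-c3ccccc3)nc21`: 15300 nM
compound 2, `Nc1nn(CC(=O)NC2CC2)c2nc(-c3ccccc3)cc(C(F)(F)F)c12`: "not active" (no number reported)
compound 3, `Nc1nn(CC(=O)NCc2ccco2)c2nc(-c3ccccc3)cc(C(F)(F)F)c12`: 7700 nM

In a functional assay on A549 cells (Homo sapiens) for cytotoxicity, read by MTT assay, with a stated time of 24 h (a higher number here means a weaker inhibitor, a lower number a stronger inhibitor), compound 1 gives 15300 nM, the higher of the two numbers recorded. Among the measured compounds shown here, compound 3 gives 7700 nM, and the only measured step in the set, a 2.0-fold lower number from compound 1 to compound 3 (0.30 log units; within the scatter), lies within the scatter. Compound 2, with a cyclopropyl group on the amide nitrogen, is reported as "not active" (no number reported) with no number, so it shows that a change at this amide nitrogen can also remove measurable activity.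

Compound 4, `CC(NC(=O)Cn1nc(N)c2c(C(F)(F)F)cc(-c3ccccc3)nc21)C(=O)O`, differs from compound 1 in one place: 1-carboxyethyl in place of methyl on an amide-type nitrogen. For the measured compounds named here, no measured step exchanges the methyl for a 1-carboxyethyl group, so the expectation rests on the single step measured at this position and on the silence of compound 2. Since that step stayed within the scatter, compound 4 is expected to stay close to compound 1, with an expected step of a 1.3-fold higher number from compound 1 to compound 4 (0.12 log units; within the scatter). The estimate for compound 4 is 20000 nM, with a range from 7000 nM to 60000 nM.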

Compound 4, half-maximal inhibitory concentration: 25600 nM
Compound 4: the middle estimate sits 1.3-fold (0.11 log units) below what was measured, within the range that was stated.
By their numbers in this assay, from the lowest: compounds 3, 1 and 4 (each within the scatter of the next, the first and the last beyond it).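

In this assay, the 1-carboxyethyl group on the amide-type nitrogen still gives a number, and a 1.7-fold higher number from compound 1 to compound 4 (0.22 log units; within the scatter) shows that this exchange of methyl for a larger group carrying a carboxylic acid has no effect that can be separated from the scatter. Against the furan-bearing group, however, a 3.3-fold higher number from compound 3 to compound 4 (0.52 log units; beyond the scatter) gives the first step at this position to go beyond the scatter, although it remains modest. Compounds 1, 3 and 4 all give numbers with different groups here, while compound 2 goes against any general tolerance at this nitrogen, and no measurement on hand explains these differences.

The compounds shown do not separate the effect of the carboxylic acid from that of the methyl branch beside it in the name-bearing group. On these data alone, how a longer chain ending in a carboxylic acid, or an amine in its place, would read also remains open.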